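A few compounds are considered here, and "the series" means these few. Any claim that something is new, unique, unknown or untested is made for them only; others in the source may bear on it.

In a functional assay on MCF7 cells (Homo sapiens) for inhibition, read by sulforhodamine B assay (a higher number here means a weaker inhibitor of growth, a lower number a stronger inhibitor of growth), compound 3 `COc1cc(-c2ccc(-c3ccc(-c4nc5cc(C)ccc5[nH]4)cc3)cc2)cc(OC)c1OC` gives 170 nM. Compound 2 `COc1ccc(-c2ccc(-c3ccc(-c4nc5cc(C)ccc5[nH]4)cc3)cc2)cc1OC` gives 190 nM, level with compound 3 within the scatter. Compound 1 `c1ccc(-c2ccc(-c3ccc(-c4nc5ccccc5[nH]4)cc3)cc2)cc1`, which carries neither the methyl nor any methoxy, gives 39200 nM, far beyond the scatter from the other two.

Compound 4 `COc1cc(-c2ccc(-c3ccc(-c4nc5ccccc5[nH]4)cc3)cc2)cc(OC)c1OC` keeps the methoxy groups of compound 3 and changes in one place: hydrogen in place of methyl on an aromatic carbon. This is hydrogen in place of methyl on an aromatic carbon, 5-methyl-1H-benzimidazol-2-yl to 1H-benzimidazol-2-yl.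

Among the compounds with values here, no measured step isolates this change. Within the data shown here, the only step available, a 1.1-fold lower number from compound 2 to compound 3 (0.05 log units; within the scatter), concerns a methoxy and stays within the scatter, so it gives no size for the methyl. Among the measured compounds shown here, the sole indirect evidence is compound 1 at 39200 nM, whose gap from compound 3 combines loss of the methyl with loss of the methoxy groups. That gap cannot be divided between them, so only part of it is expected to apply here, and the direction expected is towards a higher number in this assay. The expected change is a 7.1-fold higher number from compound 3 to compound 4 (0.85 log units; beyond the scatter), a moderate estimate held with wide uncertainty. Compound 4 is estimated at 1200 nM, with an expected range of 200 nM to 8000 nM.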

Compound 4, concentration for 50% growth inhibition: 6380 nM
The estimate for compound 4 lay 5.3-fold (0.73 log units) below the measured number, and the stated range covers the measured number.
By their numbers in this assay, from the lowest: compounds 3 and 2 (each within the scatter of the next); then compound 4; then compound 1.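

In this assay, the change from 5-methyl-1H-benzimidazol-2-yl to 1H-benzimidazol-2-yl now has a size of its own (a 38-fold higher number from compound 3 to compound 4 (1.57 log units; beyond the scatter)), a large step for the loss of a single carbon, and one that lies beyond the scatter. Within the data shown here, the only earlier step (a 1.1-fold lower number from compound 2 to compound 3 (0.05 log units; within the scatter)) lies within the scatter, so the series now shows a position where a small change moves the number strongly, while the added methoxy in that pair does not. No measurement among these compounds explains the size of this step.

As far as these compounds go, whether the methyl is specifically favoured at this aromatic carbon remains open, since only methyl and hydrogen appear there, and an ethyl, a chlorine, an amine or a carboxylic acid in the same place could separate a need for that particular group from a more general tolerance of substitution. From the compounds shown here alone, it is also open whether the step carries over to the dimethoxy compound 2, which has no partner lacking the methyl, or to a core without any methoxy groups.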